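The source may hold more compounds than are shown below. What is called first, only, known or untested is meant among the compounds shown, and "the series" means these compounds.

Measured compounds:
compound 1 `Cc1nc(C(NC(=O)C(=O)Nc2ccc(Cl)cc2)C2CCCCN2C)sc1CCO`: 88000 nM
compound 2 `CC(=O)c1ccc(NC(=O)C(=O)NC(c2nc(C)c(CCO)s2)C2CCCCN2)cc1`: > 48300 nM
compound 3 `CC(=O)N1CCCCC1C(NC(=O)C(=O)Nc1ccc(Cl)cc1)c1nc(C)c(CCO)s1`: > 84000 nM

In an ADME assay on MT2 cells (Homo sapiens) for cytotoxicity, read by XTT assay, with a stated time of 4 days (a lower number here means that less compound is tolerated, a higher number that more compound is tolerated), compound 1 gives 88000 nM. For compound 2 the assay reports only a limit, > 48300 nM. For compound 3 the assay likewise reports only a limit, > 84000 nM. Compound 3 therefore stands at a limit, and the step that the limit leaves unreadable from compound 1 to compound 3 cannot be sized because the limit of > 84000 nM in this assay, at which 1 of the 3 values shown sits, caps the reading. Compound 4 `Cc1nc(C(NC(=O)C(=O)Nc2ccc(Cl)cc2)C2CCCCN2)sc1CCO` differs from compound 3 by hydrogen in place of acetyl on an amine nitrogen in a ring. For the measured compounds named here, no measured step bears on this change beyond the unreadable one, and compound 2, which carries the same unsubstituted ring nitrogen, sits at the limit of > 48300 nM in this assay, at which 1 of the 3 values shown sits. No step beyond the scatter is expected; compound 4 is estimated at 85000 nM (40000 nM to 200000 nM), an expected step that the limit leaves unreadable from compound 3 to compound 4.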

Compound 4, half-maximal cytotoxic concentration: > 62000 nM
Compound 4: only a limit was reported; the forecaster's own chance of this, stated with the estimate: 60%; the middle value lies beyond the limit too.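

In this assay compound 4 gives only a limit, > 62000 nM. Its steps from compound 1, compound 2 and compound 3 cannot be read. The compounds shown leave open how far changing the group on the ring nitrogen shifts the tolerated concentration.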